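Arene swap on the shared core: compound 2 to compound 3

This account rests on a few compounds, and the source may have more. Where it says the series, first, only, none or still open, it means among the compounds named here.

Compound 1 `CC1=CC[C@@H]([C@@](C)(O)CCCC(C)(C)NC(=S)N/N=C\c2ccc(O)cc2)CC1` carries a 4-hydroxyphenyl group on the carbon with a double bond to nitrogen; in a functional assay on OVCAR-3 cells (Homo sapiens) for cytotoxicity, read by sulforhodamine B assay (on this read-out lower numbers stand for stronger inhibition of growth and higher numbers for weaker inhibition of growth), compound 1 gives 6230 nM. Compound 2 `CC1=CC[C@@H]([C@@](C)(O)CCCC(C)(C)NC(=S)N/N=C\c2cccc([N+](=O)[O-])c2)CC1` carries a 3-nitrophenyl group at the same place, and in this assay compound 2 gives 8510 nM. Among the compounds with values here, the only measured step, a 1.4-fold higher number from compound 1 to compound 2 (0.14 log units; within the scatter), shows that exchanging one arene for another at this position left the read-out essentially unchanged. Within the data shown here, on the numbers so far compound 2 stands together with compound 1, the gap between them lying within the scatter.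

Compound 3 `CC1=CC[C@@H]([C@@](C)(O)CCCC(C)(C)NC(=S)N/N=C\c2ccccc2Cl)CC1` is the next member. The change is 2-chlorophenyl in place of 3-nitrophenyl on a carbon with a double bond to nitrogen. Among the measured compounds shown here, the step from compound 1 to compound 2 is the one comparison that bears on it, being the same kind of arene exchange at the same carbon, and it was small. Hence no step beyond the scatter is expected in this assay in either direction. The expected step is a 1.2-fold lower number from compound 2 to compound 3 (0.08 log units; within the scatter). For compound 3 the estimate in this assay is 7000 nM, with a range from 3000 nM to 16000 nM.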

Compound 3, concentration for 50% growth inhibition: 42000 nM
For compound 3 the middle estimate is 6.0-fold (0.78 log units) below the measured one; the whole stated range lies below it.
By their numbers in this assay, from the lowest: compounds 1 and 2 (each within the scatter of the next); then compound 3.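

In this assay the arene on the carbon with a double bond to nitrogen is not a freely exchangeable position: 2-chlorophenyl gives a 4.9-fold higher number from compound 2 to compound 3 (0.69 log units; beyond the scatter) and a 6.7-fold higher number from compound 1 to compound 3 (0.83 log units; beyond the scatter) and so gives weaker inhibition of growth than either earlier arene, both steps lying beyond the scatter. The earlier exchange of 4-hydroxyphenyl for 3-nitrophenyl gave no step beyond the scatter, so the tolerance it seemed to show extends to those two arenes only and not to every substituted phenyl on the shared core. No measurement at hand accounts for the step, and the count of hydrogen-bond acceptors that differs between 3-nitrophenyl and 2-chlorophenyl stands here as a count only.

On these data alone, the three arenes differ both in the group carried and in the number in its name, so the two changes cannot be separated, and it remains open whether chlorine in another place on the phenyl ring would read like compound 3 or like compound 1. As far as these compounds go, it is also open how a phenyl ring carrying an amine or a carboxylic acid would read at this carbon.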